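Hydroxy for Chloro on Two Different Cores

The source may report more compounds than this note shows. Statements on the series, on what has been measured and on what is new or still open speak of the compounds shown alone.

Compound 1 `Cn1c(SCC(=O)Nn2c(COc3ccc(Cl)cc3Cl)nc3ccccc3c2=O)nc(-c2ccc(Cl)cc2)c(C#N)c1=O` and compound 2 `Cn1c(SCC(=O)Nn2c(COc3ccc(Cl)cc3Cl)nc3ccccc3c2=O)nc(-c2ccc(O)cc2)c(C#N)c1=O` are built on one core, while compound 3 `N#Cc1c(Nc2ccc(Cl)cc2)nc(SCC(=O)Nn2c(COc3ccc(Cl)cc3Cl)nc3ccccc3c2=O)nc1-c1ccccc1` is built on another; the difference between the two cores is not broken down here. In a functional assay on the whole organism (strain albino) for inhibition, with Rattus norvegicus as the target, read by paw edema, with stated times of 1 h and 2 h, at a dose of 100 mg/kg by the oral route (a higher number here means more inhibition at the dose given (going by the name of the read-out), a lower number less inhibition), compound 1 gives 73.7% and compound 2 gives 86%. The change between them, (hydroxy in place of chloro on an aromatic carbon), produced a step of a number 12.3 percentage points higher from compound 1 to compound 2 (beyond the scatter). In this assay compound 3 gives 57.9%, the lowest of the three numbers. Compound 4 `N#Cc1c(Nc2ccc(O)cc2)nc(SCC(=O)Nn2c(COc3ccc(Cl)cc3Cl)nc3ccccc3c2=O)nc1-c1ccccc1` differs from compound 3 by hydroxy in place of chloro on an aromatic carbon, which is the same change as that between compound 1 and compound 2, now made on the second core. Within the data shown here, for compound 4 in this assay the expected step is a number 10.1 percentage points higher from compound 3 to compound 4 (beyond the scatter), set somewhat smaller than the one earlier step, because a number 12.3 percentage points higher from compound 1 to compound 2 (beyond the scatter) rests on a single pair and on a different core. The estimate for compound 4 in this assay is 68%, with a range from 55% to 80%.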

Compound 4, a percentage reported as inhibition, in the whole organism at one dose (the size of the read-out at that dose, not a potency): 59.7%
Compound 4: the middle estimate sits 8.3 percentage points above what was measured; the range from low to high includes it.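

Among these compounds, on the second core, hydroxy in place of chloro gives a step of a number 1.8 percentage points higher from compound 3 to compound 4 (within the scatter) in this assay, so the two compounds cannot be told apart by this read-out, whereas the same change on the first core gave a step beyond the scatter. Yet the two steps themselves do not separate: the same change on two cores in this assay, a number 12.3 percentage points higher (beyond the scatter) from compound 1 to compound 2 and a number 1.8 percentage points higher (within the scatter) from compound 3 to compound 4, 10.5 percentage points apart, within the scatter of two such steps

The step seen on the first core is therefore not repeated on the second, but this does not show that the core alters the effect of the change; with a single pair on each core, neither a clean transfer nor a failed one is established.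

The compounds shown carry only chloro or hydroxy at this place, so whether a methoxy group, an amine or a carboxylic acid there would give a step beyond the scatter on either core remains open. Going by these compounds, compound 1 and compound 3 differ in more than one place, and what each of those differences contributes also remains open.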